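Cytotoxicity notes: from compound 2 to compound 3

The compounds below may be only part of what the source reports. "The series", "measured", "known", "first", "only" and "open" are said of these compounds alone.

Measured so far:
compound 1 `CCC1(Cc2ccccc2)OS(=O)(=O)C=C1OCc1ccccc1Cl` — >= 20000 nM
compound 2 `CCC1(Cc2ccccc2)OS(=O)(=O)C=C1NCc1ccccc1` — >= 80000 nM

In an ADME assay on HEL cells (Homo sapiens) for cytotoxicity, with a stated time of 3 days (a higher number here means that more compound is tolerated, a lower number that less compound is tolerated), compound 1 gives >= 20000 nM. That value is a limit of the assay and not a number (the limit of >= 20000 nM in this assay, at which 1 of the 2 values shown sits). In this assay compound 2 gives >= 80000 nM. This too is only a limit of the assay (the limit of >= 80000 nM in this assay, at which 1 of the 2 values shown sits). Compound 2 therefore has no fixed position on the numbers shown: both values present are limits, and neither allows a ranking of compound 1 against compound 2.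

The next compound is compound 3 `CCC1(Cc2ccccc2)OS(=O)(=O)C=C1OCC=C(C)C`. Against compound 2 it differs by (3-methylbut-2-en-1-yl)oxy in place of benzylamino on a double-bonded ring carbon.

Among the compounds with values here, no measured step between compounds is available, so the size of this change in this assay cannot be read from a precedent. With compound 2 sitting at a limit (the limit of >= 80000 nM in this assay, at which 1 of the 2 values shown sits), the expectation is no step beyond the scatter; the estimated step from compound 2 to compound 3 is a number no higher from compound 2 to compound 3 (the limit leaves the size open). Compound 3 is expected at 80000 nM, within 30000 nM to 160000 nM, with a further limit the most likely outcome.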

Compound 3, minimum cytotoxic concentration: 400000 nM
Estimate against measurement, compound 3: 5.0-fold (0.70 log units) below; the measured number lies above the stated range.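

In this assay no new step can be read from compound 1 to compound 3 or from compound 2 to compound 3: compound 1 and compound 2 stand only as limits of the assay. The compounds shown leave open how large a step (3-methylbut-2-en-1-yl)oxy in place of benzylamino gives on the shared core.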